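Cycloheptyl in place of pyridin-4-yl on the saturated ring carbon

This account rests on a few compounds, and the source may have more. Where it says the series, first, only, none or still open, it means among the compounds named here.

In a functional assay on MCF7 cells (Homo sapiens) for cytotoxicity, read by WST assay, with a stated time of 72 h (on this read-out higher numbers stand for weaker inhibition and lower numbers for stronger inhibition), compound 1 `O=C1Nc2c(ccc(F)c2F)C1(c1ccc(O)cc1)c1ccc(F)cc1` gives 2.6 nM and compound 2 `O=C1Nc2c(ccc(F)c2F)C1(c1ccncc1)c1ccc(O)cc1` gives 37 nM, so compound 2 holds the higher of the two numbers, on the weaker side. Compound 3 `O=C1Nc2c(ccc(F)c2F)C1(c1ccc(O)cc1)C1CCCCCC1` has cycloheptyl in place of pyridin-4-yl on a saturated ring carbon. For the measured compounds named here, the one measured step at this place is a 14-fold higher number from compound 1 to compound 2 (1.15 log units; beyond the scatter), a large step that brought in pyridin-4-yl in place of 4-fluorophenyl. Going by the values given here, removing pyridin-4-yl is therefore expected to recover much of that step, though no measured compound yet has a non-aromatic ring at this place, which keeps the range wide. A large move towards a lower number is expected: a 6.2-fold lower number from compound 2 to compound 3 (0.79 log units; beyond the scatter). The estimated value for compound 3 is 6 nM, within a range of 1.5 nM to 30 nM.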

Compound 3, half-maximal inhibitory concentration: 1.2 nM
Compound 3: the middle estimate sits 5.0-fold (0.70 log units) above what was measured; the whole stated range lies above it.
By their numbers in this assay, from the lowest: compound 3; then compound 1; then compound 2.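

Until now only aromatic rings stood on this saturated ring carbon; in this assay cycloheptyl shows that a seven-membered non-aromatic ring of carbon only is accepted here, with a 31-fold lower number from compound 2 to compound 3 (1.49 log units; beyond the scatter) on the exchange for pyridin-4-yl. The exchange for 4-fluorophenyl gives a 2.2-fold lower number from compound 1 to compound 3 (0.34 log units; beyond the scatter), a modest step, so among the three groups shown cycloheptyl carries the lowest number and pyridin-4-yl the highest. No measurement in hand bears on what lies behind these differences.

The compounds shown leave open whether ring size or the non-aromatic ring itself goes with the low number, a question that cyclopentyl or cyclohexyl at this place would address. Also open, from the compounds shown here alone, is how an open chain such as n-butyl, or an amine on the cycloheptyl ring, would read in this assay at this position.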